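The source may hold more compounds than are shown below. What is called first, only, known or untested is meant among the compounds shown, and "the series" means these compounds.

Measured compounds:
Compound 1, `C(#Cc1[nH]cnc2ncnc1-2)c1ccccc1`, gives 0.7 ug/mL.
Compound 2, `C(#Cc1ncnc2c1ncn2C1CCOCC1)c1ccccc1`, gives 0.5 ug/mL.

Both numbers come from a functional assay on K562 cells (Homo sapiens) for inhibition, read by thymidine incorporation, with a stated time of 48 h; a higher number here means a weaker inhibitor, a lower number a stronger inhibitor. Compound 2 has the lower of the two values, but its nearest neighbour is compound 1, whose number sits within the scatter of repeated measurements, so the two cannot be ordered with confidence. The shared core of compound 1 carries a free ring hydrogen where compound 2 carries an oxan-4-yl group, and the thymidine incorporation read-out barely moves between them.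

Compound 3, `Clc1nc2c(C#Cc3ccccc3)ncnc2n1C1CCOCC1`, has not yet been tested in this assay. It differs from compound 2 in one place: chloro in place of hydrogen on an aromatic carbon. Within the data shown here, no measured pair in this set shows what such a substitution does, so the expectation rests on the small spread seen so far and on the modest size of the change. The account therefore expects compound 3 to land close to compound 2, with the step of a 1.3-fold lower number from compound 2 to compound 3 (0.10 log units; within the scatter) no larger than the scatter and leaning, if anywhere, toward a slightly lower number. The estimate for compound 3 in this assay is 0.4 ug/mL, with a range from 0.15 ug/mL to 1.2 ug/mL.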

Compound 3, half-maximal inhibitory concentration: 6.1 ug/mL
For compound 3 the middle estimate is 15-fold (1.18 log units) below the measured one, and the stated range ends below it.
By their numbers in this assay, from the lowest: compounds 2 and 1 (each within the scatter of the next); then compound 3.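

In this assay the swap of hydrogen for chloro, on the aromatic carbon between two ring nitrogen atoms and next to the ring atom that bears an oxan-4-yl group, gives a 12-fold higher number from compound 2 to compound 3 (1.09 log units; beyond the scatter) for the addition of one chlorine atom. This is the first step shown that lies beyond the scatter, and so the first sign that inhibition of thymidine incorporation in these cells responds to what sits at this carbon, a sensitivity that the close values of the two earlier compounds gave no hint of. Nothing measured here speaks to why the number rises so far.

Whether the loss belongs to chloro itself or would follow any group other than hydrogen at this carbon stays open, as chloro is the only replacement shown, and a methyl group, an amine or a nitrile there would separate these readings. As far as these compounds go, it is also open whether chloro at this carbon would have the same effect on the core of compound 1, which carries a free ring hydrogen in place of the oxan-4-yl group.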